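Series notes: pyridin-4-yl replaced by 4-methoxyphenyl

This account rests on a few compounds, and the source may have more. Where it says the series, first, only, none or still open, it means among the compounds named here.

Compound 1 `Cc1cn(C2CCN(Cc3cccc(Oc4ccncc4)c3)CC2)c(=O)[nH]c1=O` has no number in an ADME assay on MRC5 cells (Homo sapiens) for cytotoxicity, read by fluorescence and resazurin assay, with a stated time of 3 days; a higher number here means a weaker inhibitor, a lower number a stronger inhibitor; the record for compound 1 stands as "not determined" (no result reported). Compound 2 `Cc1cn(C2CCN(Cc3cccc(Oc4ccc(O)cc4)n3)CC2)c(=O)[nH]c1=O` is in the same position, compound 2 being recorded as "not determined" (no result reported). Compound 3 `Cc1cn(C2CCN(Cc3ccnc(Oc4ccccc4)c3)CC2)c(=O)[nH]c1=O` gives only a limit of the assay, compound 3 reading > 64000 nM. Among the three entries, then, the sole quantitative information is the limit of > 64000 nM in this assay, at which 1 of the 3 values shown sits. Compound 4 `COc1ccc(Oc2cccc(CN3CCC(n4cc(C)c(=O)[nH]c4=O)CC3)c2)cc1` is the untested partner of compound 1, differing by 4-methoxyphenyl in place of pyridin-4-yl on an oxygen on an aromatic ring. For the measured compounds named here, with no measured step in the set, the size of the change from compound 1 to compound 4 cannot be anchored; the expectation is no movement beyond scatter, with compound 4 again probably reaching the limit. Compound 4 is estimated at 64000 nM, with a range from 25000 nM to 200000 nM.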

Compound 4, half-maximal inhibitory concentration: 28000 nM
Compound 4: the middle estimate sits 2.3-fold (0.36 log units) above what was measured; the measured number falls inside the stated range.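

No step can be read from compound 1 to compound 4: compound 1 has no single number in this assay, so compound 4 at 28000 nM stands alone. What replacing pyridin-4-yl with 4-methoxyphenyl does in this assay stays open, and nothing shown bears on it.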